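From compound 1 to its chloro analogue, compound 4

This account rests on a few compounds, and the source may have more. Where it says the series, first, only, none or still open, it means among the compounds named here.

Measured in a functional assay on MCF7 cells (Homo sapiens) for inhibition, with a stated time of 48 h (on this read-out higher numbers stand for weaker inhibition and lower numbers for stronger inhibition), so far:
compound 1 `COc1cc(Sc2c[nH]c3ccccc23)cc(OC)c1OC` gives 34 nM
compound 2 `COc1cc(Sc2c(C)[nH]c3ccccc23)cc(OC)c1OC` gives 46 nM
compound 3 `Cc1cc(C)cc(Sc2c[nH]c3ccc(Cl)cc23)c1` gives 1200 nM

Compound 1 sits at the low end of these numbers alongside compound 2, and compound 3 stands clearly apart at the high end. The next compound, compound 4 `COc1cc(Sc2c[nH]c3ccc(Cl)cc23)cc(OC)c1OC` in the series, follows from compound 1 by one change: chloro in place of hydrogen on an aromatic carbon with chloro in place of hydrogen on an aromatic carbon. Going by the values given here, no measured step isolates this change. Among the compounds with values here, the only measured step is a 1.4-fold higher number from compound 1 to compound 2 (0.13 log units; within the scatter) and it concerns a methyl in place of hydrogen on an aromatic carbon, so it offers only a loose guide. Compound 3 also carries the chloro and gives 1200 nM but differs from compound 4 elsewhere as well, so it only hints at an upward direction. A small rise is therefore expected, an estimated 1.8-fold higher number from compound 1 to compound 4 (0.25 log units; within the scatter) in this assay that may not clear the usual scatter. The expected value for compound 4 is 60 nM with an estimated range from 15 nM to 250 nM in this measurement.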

Compound 4, half-maximal inhibitory concentration: 77 nM
Compound 4: the middle estimate sits 1.3-fold (0.11 log units) below what was measured; measured number inside the range.
By their numbers in this assay, from the lowest: compounds 1, 2 and 4 (each within the scatter of the next, the first and the last beyond it); then compound 3.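

In this assay, chloro in place of hydrogen on an aromatic carbon of the six-membered ring gives a 2.3-fold higher number from compound 1 to compound 4 (0.36 log units; beyond the scatter), a modest step but the first single change shown here to lie beyond the scatter. Compound 2 had shown only that a methyl on another aromatic carbon leaves the number within the scatter, so this position is the first place where one change visibly weakens inhibition, while compound 4 still gives 77 nM in this read-out. Nothing available explains why this step occurs.

As far as these compounds go, whether fluoro, bromo or an amine at this carbon would shift the number as chloro does remains open, as does the effect of chloro on another carbon of this ring. Also open, from the compounds shown here alone, is whether the chloro step would keep its size in the presence of the methyl of compound 2.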